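The source may report more compounds than this note shows. Statements on the series, on what has been measured and on what is new or still open speak of the compounds shown alone.

Of the compounds shown here, two sharing one core have been measured so far in a functional assay on K562 cells (Homo sapiens) for cytotoxicity, read by sulforhodamine B assay; on this read-out higher numbers stand for weaker inhibition of growth and lower numbers for stronger inhibition of growth. Compound 1 `COc1ccc(/C=N\NC(=S)NC(C)(C)CCC[C@](C)(O)[C@@H]2CC=C(C)CC2)cc1` gives 34900 nM, and compound 2 `CC1=CC[C@@H]([C@@](C)(O)CCCC(C)(C)NC(=S)N/N=C\c2ccccc2[N+](=O)[O-])CC1` gives 7840 nM, the lower of the two numbers. Compound 3 `CC1=CC[C@@H]([C@@](C)(O)CCCC(C)(C)NC(=S)N/N=C\c2ccc([N+](=O)[O-])cc2)CC1` has not yet been measured. It differs from compound 2 as follows: 4-nitrophenyl in place of 2-nitrophenyl on a carbon with a double bond to nitrogen. In words, it carries 4-nitrophenyl in place of 2-nitrophenyl on a carbon with a double bond to nitrogen. Going by the values given here, only one measured step bears on this change: a 4.5-fold lower number from compound 1 to compound 2 (0.65 log units; beyond the scatter). Among the compounds with values here, that modest step replaced 4-methoxyphenyl with 2-nitrophenyl, so the group and the place of its substituent changed together, and no measured pair isolates the move made here. Compound 3 keeps the nitrophenyl of compound 2 while sharing the 4-substituted pattern of compound 1, so a small move towards a higher number in this assay is expected, perhaps none beyond the scatter. The expected step is a 1.4-fold higher number from compound 2 to compound 3 (0.15 log units; within the scatter). For compound 3 the estimated value is 11000 nM, with an expected range from 4500 nM to 27000 nM.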

Compound 3, concentration for total growth inhibition: 9560 nM
The estimate for compound 3 lay 1.2-fold (0.06 log units) above the measured number; low and high end bracket the measured number.
By their numbers in this assay, from the lowest: compounds 2 and 3 (each within the scatter of the next); then compound 1.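

Moving the nitro group leaves the number in this assay essentially unchanged, with a 1.2-fold higher number from compound 2 to compound 3 (0.09 log units; within the scatter), so 2-nitrophenyl and 4-nitrophenyl cannot be told apart on this carbon with a double bond to nitrogen. Going by these compounds alone, compound 3 also supplies the first clean comparison of the group itself: with the substituent kept in the same place on the aromatic ring, nitro in place of methoxy gives a 3.7-fold lower number from compound 1 to compound 3 (0.56 log units; beyond the scatter), which accounts for most of the earlier mixed step, a 4.5-fold lower number from compound 1 to compound 2 (0.65 log units; beyond the scatter), and shows that this step followed the change of group rather than the shift in place. No available evidence explains either result.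

The compounds shown leave open whether the lower number is particular to nitro or would also appear with another group in that place on the aromatic ring, such as a nitrile, an amine or a carboxylic acid. They also leave open how a plain phenyl, with no substituent at all, would compare with the nitrophenyl pair in this assay, and so whether nitro lowers the number or methoxy raises it.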